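An Ethyl Branch on the Acetoxy Side Chain

The source may report more compounds than this note shows. Statements on the series, on what has been measured and on what is new or still open speak of the compounds shown alone.

Measured compounds:
Compound 1 `CC(C)=CC[C@@H](OC(=O)CCO)C1=CC(=O)c2c(O)ccc(O)c2C1=O` gives 55300 nM in a functional assay on DU-145 cells (Homo sapiens) for cytotoxicity, read by MTT assay; a lower number here means a stronger inhibitor, a higher number a weaker inhibitor.
Compound 2 `COC(C)CO[C@H](CC=C(C)C)C1=CC(=O)c2c(O)ccc(O)c2C1=O` gives 16600 nM in this assay.
Compound 3 `CC(=O)OCCO[C@H](CC=C(C)C)C1=CC(=O)c2c(O)ccc(O)c2C1=O` gives 15500 nM in this assay.

Compound 3 stands at the lowest of the three numbers in this assay, but this is a weak standing: compound 2 sits within the scatter of it (a 1.1-fold lower number from compound 2 to compound 3 (0.03 log units; within the scatter)), and only compound 1 is clearly separated (a 3.6-fold lower number from compound 1 to compound 3 (0.55 log units; beyond the scatter)). The two steps that moved the numbers beyond the scatter, a 3.3-fold lower number from compound 1 to compound 2 (0.52 log units; beyond the scatter) and a 3.6-fold lower number from compound 1 to compound 3 (0.55 log units; beyond the scatter), both replace the whole (2-hydroxyethyl)carbonyl group and are modest in size.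

Compound 4 `CCC(CO[C@H](CC=C(C)C)C1=CC(=O)c2c(O)ccc(O)c2C1=O)OC(C)=O` differs from compound 3 by ethyl in place of hydrogen on a saturated chain carbon bound to an oxygen next to a carbonyl group and a saturated chain carbon. Among the measured compounds shown here, no measured step adds a substituent to the side chain in this way. The nearest comparison is the exchange of acetoxymethyl for 1-methoxyethyl, which left the number unchanged within the scatter (a 1.1-fold lower number from compound 2 to compound 3 (0.03 log units; within the scatter)); that step already reshuffles a methyl along the same chain without effect. The ethyl entering in compound 4 is a small addition of the same kind, so no step beyond the scatter is expected in this assay.

Compound 4 is therefore expected to give about 14000 nM, within 6000 nM to 35000 nM. This estimate for compound 4 means an expected 1.1-fold lower number from compound 3 to compound 4 (0.04 log units; within the scatter).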

Compound 4, half-maximal inhibitory concentration: 25400 nM
The estimate for compound 4 lay 1.8-fold (0.26 log units) below the measured number, within the range that was stated.
By their numbers in this assay, from the lowest: compounds 3, 2 and 4 (each within the scatter of the next); then compound 1.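

In this assay, the ethyl in place of hydrogen on a saturated chain carbon bound to an oxygen next to a carbonyl group and a saturated chain carbon is the first change shown that adds to the side chain rather than exchanging one group for another, and the step stays within the scatter (a 1.6-fold higher number from compound 3 to compound 4 (0.21 log units; within the scatter)). The comparison with the 1-methoxyethyl group of compound 2 also stays within the scatter (a 1.5-fold higher number from compound 2 to compound 4 (0.18 log units; within the scatter)), so the numbers do not separate the 2-acetoxybutyl, 2-acetoxyethyl and 2-methoxypropyl side chains, while 2-acetoxybutyl in place of the (2-hydroxyethyl)carbonyl group of compound 1 remains a modest step beyond the scatter (a 2.2-fold lower number from compound 1 to compound 4 (0.34 log units; beyond the scatter)). No evidence is available to explain why these side chains give the numbers they do.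

The compounds shown leave open whether a longer chain on this carbon, such as butyl, would also stay within the scatter of compound 3, or whether an amine or a carboxylic acid there would move the number beyond it. They also leave open what a free hydroxyl in place of the acetoxy group would do on the same side chain.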